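A few compounds are considered here, and "the series" means these few. Any claim that something is new, unique, unknown or untested is made for them only; others in the source may bear on it.

Measured compounds in an assay on CHO cells for displacement of a labelled ligand from 5-hydroxytryptamine receptor 1B (Homo sapiens); on this read-out higher numbers stand for weaker inhibition and lower numbers for stronger inhibition:

compound 1 `c1cc(CN2CCN(CCCc3c[nH]c4ccc(-n5cnnc5)cc34)CC2)ccn1`: 23 nM
compound 2 `FC(F)(F)c1ccc(CN2CCN(CCCc3c[nH]c4ccc(-n5cnnc5)cc34)CC2)cc1`: 282 nM

For the measured compounds named here, compound 2 stands at the highest of the two numbers so far; the only neighbour, compound 1, sits at a lower number by a 12-fold higher number from compound 1 to compound 2 (1.09 log units; beyond the scatter). The next step removes the aryl methyl group from the ring nitrogen of compound 2 altogether, giving compound 3 `c1cc2[nH]cc(CCCN3CCNCC3)c2cc1-n1cnnc1`, where (hydrogen in place of 4-(trifluoromethyl)benzyl on an amine nitrogen in a ring).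

Going by the values given here, the single measured step bears on this only indirectly: it shows that what sits on this ring nitrogen matters a great deal in this assay, the swap of one aryl for another already giving a 12-fold higher number from compound 1 to compound 2 (1.09 log units; beyond the scatter). Among the compounds with values here, no step shows the bare ring nitrogen itself. The direction is therefore open; loss of the whole group is taken here as a change of comparable size to the aryl swap, most likely toward a somewhat lower number than compound 2, with wide uncertainty.

For compound 3 the expected value in this assay is 120 nM, within 25 nM to 600 nM, which means an expected step of a 2.4-fold lower number from compound 2 to compound 3 (0.37 log units; beyond the scatter).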

Compound 3, half-maximal inhibitory concentration: 145 nM
Beside the measured number, compound 3's estimate is 1.2-fold (0.08 log units) below it; the range from low to high includes it.
By their numbers in this assay, from the lowest: compound 1; then compounds 3 and 2 (each within the scatter of the next).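

In this assay, hydrogen in place of 4-(trifluoromethyl)benzyl on the ring nitrogen gives a 1.9-fold lower number from compound 2 to compound 3 (0.29 log units; within the scatter) and so leaves the two compounds within the usual scatter of each other. The (pyridin-4-yl)methyl group behaves differently: hydrogen in its place gives a 6.3-fold higher number from compound 1 to compound 3 (0.80 log units; beyond the scatter) and so separates compound 1 from the unsubstituted ring nitrogen of compound 3. On this position, then, only the (pyridin-4-yl)methyl group of these two shows stronger inhibition than hydrogen, and no supporting measurement is available to explain why.

From the compounds shown here alone, it remains open whether this advantage depends on the ring nitrogen of the pyridine and its location, as a (pyridin-3-yl)methyl or (pyridin-2-yl)methyl group or an unsubstituted benzyl group would test. Also open, going by these compounds, is whether a longer chain between the pyridine and the ring nitrogen keeps the number of compound 1.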